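The compounds below may be only part of what the source reports. "The series", "measured", "known", "first", "only" and "open" are said of these compounds alone.

Working notes on the urea series.

Compound 1 `Cc1cccc(NC(=O)Nc2nnc(Sc3ncnc4scc(-c5ccncc5)c34)s2)c1` is the reference point here; in a functional assay on PC-3 cells (Homo sapiens) for antiproliferative activity, read by MTT assay, with a stated time of 48 h (a higher number here means a weaker inhibitor, a lower number a stronger inhibitor), compound 1 gives 5200 nM, the lower of the two numbers recorded, with compound 2 `O=C(Nc1cccc(C(F)(F)F)c1)Nc1nnc(Sc2ncnc3scc(-c4ccncc4)c23)s1` giving 11500 nM and standing apart from it beyond the scatter. Within the data shown here, the one measured step on the aryl urea side is a 2.2-fold higher number from compound 1 to compound 2 (0.34 log units; beyond the scatter).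

Compound 3 `O=C(Nc1ccc(Cl)c(C(F)(F)F)c1)Nc1nnc(Sc2ncnc3scc(-c4ccncc4)c23)s1` differs from compound 1 by 4-chloro-3-(trifluoromethyl)phenyl in place of 3-methylphenyl on an amide-type nitrogen. Among the measured compounds shown here, the step from compound 1 to compound 2 bears on this change directly, since the trifluoromethyl is carried over; the chloro has no counterpart among the measured compounds, so its contribution is unknown. The expectation is therefore that compound 3 moves in the same direction as compound 2 did, by a modest step, with wide uncertainty: the step of a 1.7-fold higher number from compound 1 to compound 3 (0.24 log units; within the scatter) is estimated.

Compound 3 is expected to give about 9000 nM in this assay, within a range of 3000 nM to 30000 nM.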

Compound 3, half-maximal inhibitory concentration: 12100 nM
Compound 3: middle estimate off by 1.3-fold (0.13 log units), on the low side; the measured number falls inside the stated range.
By their numbers in this assay, from the lowest: compound 1; then compounds 2 and 3 (each within the scatter of the next).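

With chloro in place of hydrogen on an aromatic carbon, the data give a 1.1-fold higher number from compound 2 to compound 3 (0.02 log units; within the scatter) in this assay, so compound 2 and compound 3 cannot be told apart and this aryl position shows no readable effect of chloro alongside trifluoromethyl. The full replacement of 3-methylphenyl by 4-chloro-3-(trifluoromethyl)phenyl on the amide-type nitrogen gives a 2.3-fold higher number from compound 1 to compound 3 (0.37 log units; beyond the scatter), which places compound 3 with compound 2 on the higher side of compound 1, next to the earlier 2.2-fold higher number from compound 1 to compound 2 (0.34 log units; beyond the scatter). No supporting data on the cause of these differences are available.

From the compounds shown here alone, the effect of chloro on the 3-methylphenyl urea remains open, as does the effect of chloro without trifluoromethyl on the ring. Going by these compounds, it is also open whether a methoxy group, an amine or a carboxylic acid on this aryl ring would keep the number near that of compound 1 or move it beyond the scatter.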